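From a Bromophenyl Group to a Chloro-Cyanophenyl Group

The source may report more compounds than this note shows. Statements on the series, on what has been measured and on what is new or still open speak of the compounds shown alone.

Four compounds share one core. Compound 1 `O=c1c2cnn(-c3ccc(F)cc3)c2ncn1CC1(O)CCN(Cc2cccc(Cl)c2)CC1` has no result reported: in an assay on Sf21 cells for inhibition of ubiquitin carboxyl-terminal hydrolase 7 (Homo sapiens), read by spectrophotometry, with stated times of 30 min and 2 h (a higher number here means a weaker inhibitor, a lower number a stronger inhibitor), compound 1 gives "not determined" (no result reported). Compound 3 `O=c1c2cnn(-c3ccc(F)cc3)c2ncn1CC1(O)CCN(Cc2ccc(C(F)(F)F)cc2)CC1` has no result reported either: in this assay compound 3 gives "not determined" (no result reported). Among the measured compounds shown here, compound 2 `O=c1c2cnn(-c3ccc(F)cc3)c2ncn1CC1(O)CCN(Cc2ccccc2Br)CC1` stands alone: in this assay compound 2 gives 3100 nM, the only number in this set, so it cannot be ranked against anything. Compound 4 `N#Cc1cc(Cl)ccc1CN1CCC(O)(Cn2cnc3c(cnn3-c3ccc(F)cc3)c2=O)CC1` has not been measured yet. It differs from compound 2 in one place: 4-chloro-2-cyanophenyl in place of 2-bromophenyl on a saturated chain carbon bound to an amine nitrogen in a ring. For the measured compounds named here, no step between two measured compounds is available to show how such a change has behaved, so nothing anchors its direction. A step no larger than the usual scatter, in either direction, is expected, and the expected step is a 1.6-fold lower number from compound 2 to compound 4 (0.19 log units; within the scatter). Compound 4 is estimated at 2000 nM, with a range from 500 nM to 8000 nM.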

Compound 4, half-maximal inhibitory concentration: 11400 nM
The estimate for compound 4 lay 5.7-fold (0.76 log units) below the measured number; the measured number lies above the stated range.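

Among the compounds shown here, this is the first readable change at this place, on a saturated chain carbon bound to an amine nitrogen in a ring. In this assay, 4-chloro-2-cyanobenzyl in place of 2-bromobenzyl gives a 3.7-fold higher number from compound 2 to compound 4 (0.57 log units; beyond the scatter), so this swap weakens inhibition by a modest step. Nothing available explains the step.

As far as these compounds go, the chlorine and nitrile enter together, so their separate contributions remain unknown. Also open, from the compounds shown here alone, is how an unsubstituted benzyl or a benzyl carrying a methoxy group or an amine would compare with compound 2.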